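The compounds below may be only part of what the source reports. "The series", "measured", "known", "first", "only" and "open" are said of these compounds alone.

Measured in a functional assay (Left cardiac atrium, Cavia porcellus), with a stated time of 30 min; a lower number here means that less compound is needed, a higher number that more compound is needed for the effect:
- Compound 1 `CC1=CSC(O)(c2ccccc2)c2noc(=O)n21` gives 230 nM
- Compound 2 `COc1cccc(C2(O)SC=C(C)n3c2noc3=O)c1` gives 490 nM
- Compound 3 `CCOC1(c2cccc(OC)c2)SC=C(C)n2c1noc2=O` gives 38 nM

Compound 3 has the lowest number of the three. Compound 4 `COc1cccc(C2(OCC(F)(F)F)SC=C(C)n3c2noc3=O)c1` differs from it in one place: trifluoromethyl in place of methyl on a saturated chain carbon bound to an oxygen on a saturated carbon. This puts trifluoromethyl in place of methyl on a saturated chain carbon bound to an oxygen on a saturated carbon, turning ethoxy into 2,2,2-trifluoroethoxy.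

The most relevant measured step is the large 13-fold lower number from compound 2 to compound 3 (1.11 log units; beyond the scatter), which put ethyl in place of hydrogen on that oxygen. The modest 2.1-fold higher number from compound 1 to compound 2 (0.33 log units; beyond the scatter) concerns methoxy on an aromatic carbon and says less. For the measured compounds named here, no measured pair shows a change within the ethyl itself, so the expectation is uncertain.

The expected step is a 1.2-fold higher number from compound 3 to compound 4 (0.07 log units; within the scatter), not beyond the scatter. Compound 4 is estimated at 45 nM, with an expected range from 14 nM to 150 nM.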

Compound 4, half-maximal effective concentration: 320 nM
Compound 4: the middle estimate sits 7.1-fold (0.85 log units) below what was measured, and the stated range ends below it.
By their numbers in this assay, from the lowest: compound 3; then compounds 1, 4 and 2 (each within the scatter of the next, the first and the last beyond it).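

Changing the far end of the ethyl matters at this position: trifluoromethyl in place of methyl brings an 8.4-fold higher number from compound 3 to compound 4 (0.93 log units; beyond the scatter) and so removes the gain that ethyl gave on this oxygen. Placing 2,2,2-trifluoroethyl on the oxygen in place of hydrogen brings only a 1.5-fold lower number from compound 2 to compound 4 (0.19 log units; within the scatter) and leaves compound 4 level with the free hydroxyl compound. No measurement at hand explains this difference between ethyl and 2,2,2-trifluoroethyl.

Going by these compounds, it remains open whether a longer chain such as propyl, or a chain ending in an amine, would behave like ethyl or like 2,2,2-trifluoroethyl.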